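This account rests on a few compounds, and the source may have more. Where it says the series, first, only, none or still open, it means among the compounds named here.

Within the data shown here, in a functional assay on DU-145 cells (Homo sapiens) for inhibition, read by trypan blue exclusion, with a stated time of 96 h (a higher number here means a weaker inhibitor of growth, a lower number a stronger inhibitor of growth), compound 2 `Cc1ccc(S(=O)(=O)/C(=C/c2cc(C)ccc2C)C(=O)c2ccc(Cl)cc2)cc1` gives 1000 nM and so holds the lower of the two numbers so far. Compound 1 `O=C(/C(=C\c1c(O)cc(O)cc1O)SCc1ccc(Cl)c(Cl)c1)c1ccc(Cl)cc1` gives 25000 nM in the same test, a gap well beyond the scatter. These two compounds differ in more than one place, so their gap cannot be pinned on any single group.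

Compound 3 `Cc1ccc(S(=O)(=O)/C(=C/c2c(O)cc(O)cc2O)C(=O)c2ccc(Cl)cc2)cc1` departs from compound 2 in one place only. The change 2,4,6-trihydroxyphenyl in place of 2,5-dimethylphenyl on a double-bonded chain carbon bound to a double-bonded chain carbon puts 2,4,6-trihydroxyphenyl in place of 2,5-dimethylphenyl on a double-bonded chain carbon bound to a double-bonded chain carbon. Among the measured compounds shown here, no measured pair shows this swap alone, so the guidance is thin. Compound 1 also carries the 2,4,6-trihydroxyphenyl group and gives 25000 nM as the weaker inhibitor of the two, which hints at a loss, although the rest of its structure differs as well. The expected change is a 4.0-fold higher number from compound 2 to compound 3 (0.60 log units; beyond the scatter) in the direction of weaker growth inhibition, a moderate step beyond the scatter. For compound 3 the expected value is 4000 nM with 800 nM to 20000 nM as the estimated range.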

Compound 3, concentration for 50% growth inhibition: > 100000 nM
Compound 3 ended at the assay's limit; the forecaster's own chance of this, stated with the estimate: 5%; middle value at least 25-fold (1.39 log units) away from the limit.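

In this assay, among these compounds, putting 2,4,6-trihydroxyphenyl in place of 2,5-dimethylphenyl on a double-bonded chain carbon bound to a double-bonded chain carbon gives an at least 100-fold higher number from compound 2 to compound 3 (2.00 log units; beyond the scatter), the first reading of this swap on its own, and it shows that growth inhibition at this position depends heavily on which aromatic group sits there. As far as these compounds go, the number for compound 3 is a limit of the assay and not a measured value, so the true size of both steps remains open on the high side: the limit of > 100000 nM in this assay, at which 1 of the 3 values shown sits. With 2,4,6-trihydroxyphenyl held constant, (4-methylphenyl)sulfonyl in place of (3,4-dichlorobenzyl)sulfanyl on a double-bonded chain carbon bound to a carbonyl carbon and a double-bonded chain carbon gives an at least 4.0-fold higher number from compound 1 to compound 3 (0.60 log units; beyond the scatter), so the outcome with this aromatic group also depends on the second position.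

The compounds shown cannot say whether the loss follows the number of hydroxy groups or their placement, which a phenyl ring bearing one hydroxy group, or methoxy groups instead, could help to separate. Nor can they say how an amine on that ring would behave, or what the (3,4-dichlorobenzyl)sulfanyl group would do alongside 2,5-dimethylphenyl.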